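The source may report more compounds than this note shows. Statements on the series, on what has been measured and on what is new or still open speak of the compounds shown alone.

Measured compounds:

Compound 1, `c1ccc2c(c1)CN[C@@H](CN(CCN1CCNCC1)[C@H]1CCCc3cccnc31)C2`, with 96% in an ADME assay on microsomes from liver (Homo sapiens) for metabolic stability, read by LC-MS, with a stated time of 10 min, tested at 0.5 uM; on this read-out lower numbers stand for a less stable compound and higher numbers for a more stable compound.
Compound 2, `NC(=O)N1CCN(CCCN(C[C@H]2Cc3ccccc3CN2)[C@H]2CCCc3cccnc32)CC1`, with 79%.
Compound 3, `c1ccc2c(c1)CN[C@@H](CN(CC[C@H]1CCCNC1)[C@H]1CCCc3cccnc31)C2`, with 93%.

Within this set of three, compound 3 sits second highest: its nearest neighbour is compound 1, where the step reads a number 3 percentage points lower from compound 1 to compound 3 (within the scatter), and its furthest is compound 2, from which the step is a number 14 percentage points higher from compound 2 to compound 3 (beyond the scatter). The unmeasured compound 4, `c1ccc2c(c1)CN[C@@H](CN(CCCCN1CCNCC1)[C@H]1CCCc3cccnc31)C2`, differs from compound 3 by 2-(piperazin-1-yl)ethyl in place of piperidin-3-yl on a saturated chain carbon, two bonds along the chain from an amine nitrogen. This change bears on two measured steps. The first, a number 3 percentage points lower from compound 1 to compound 3 (within the scatter), shows that swapping between piperazin-1-yl and piperidin-3-yl at this place moved the number very little. The second, a number 17 percentage points lower from compound 1 to compound 2 (beyond the scatter), shows a modest loss only when a carbamoyl group was also added. Compound 4 carries a plain piperazine like compound 1, so the step of a number 1 percentage points lower from compound 3 to compound 4 (within the scatter) is expected to stay within the scatter. Compound 4 is therefore estimated at 92%, with a range from 80% to 99%.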

Compound 4, percent of the compound remaining: 82%
The estimate for compound 4 lay 10 percentage points above the measured number; the range from low to high includes it.
By their numbers in this assay, from the lowest: compounds 2 and 4 (each within the scatter of the next); then compounds 3 and 1 (each within the scatter of the next).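

The 2-(piperazin-1-yl)ethyl group shows that the length of the chain carrying the ring can matter at this place, even with a plain piperazine: the step reads a number 14 percentage points lower from compound 1 to compound 4 (beyond the scatter), and also a number 11 percentage points lower from compound 3 to compound 4 (beyond the scatter), whereas swapping piperazin-1-yl for piperidin-3-yl on the shorter chain had left the number within the scatter. In this assay, a lower number is also no longer tied to the carbamoyl group alone, since the two compounds with the longer chains stand level, with a number 3 percentage points higher from compound 2 to compound 4 (within the scatter). Nothing measured here explains why the number moves with this change.

Still open, as far as these compounds go, is how (piperazin-1-yl)methyl would read at this place, which would help show whether the number falls steadily as the chain grows. From the compounds shown here alone, it is also open whether a morpholine ring on the same chain would follow the piperazine.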